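The source may hold more compounds than are shown below. What is called first, only, known or untested is meant among the compounds shown, and "the series" means these compounds.

Measured so far in an ADME assay on BHK-21 cells (Mesocricetus auratus) for cytotoxicity, read by MTT assay, with a stated time of 96 h; on this read-out lower numbers stand for higher toxicity in this test and higher numbers for lower toxicity in this test:
Compound 1 `Clc1cccc(/N=N/N2CCCCC2)c1` gives > 100000 nM as a limit.
Compound 2 `c1ccc(/N=N/N2CCCCC2)cc1` gives > 100000 nM as a limit.

Compound 2 has no readable number and stands with the limit of > 100000 nM in this assay, at which 2 of the 2 values shown sit, as its only context. Compound 3 `Brc1cccc(/N=N/N2CCCCC2)c1` has bromo in place of hydrogen on an aromatic carbon, meta to a group of 8 heavy atoms, and the counted change is bromo in place of hydrogen on an aromatic carbon on the shared core. Within the data shown here, the one measured step that bears on this is hydrogen in place of chloro on an aromatic carbon, seen as a step that the two limits leave unreadable from compound 1 to compound 2 and offering no size to carry over. Among the measured compounds shown here, with that step as the only guide, no change beyond the scatter is expected in this assay and no direction can be named. The expected step is a number no higher from compound 2 to compound 3 (the limit leaves the size open) and remains an estimate. Compound 3 is estimated at 100000 nM with an expected range from 50000 nM to 200000 nM and a report as a limit is the likeliest outcome.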

Compound 3, half-maximal cytotoxic concentration: > 100000 nM
Compound 3 ended at the assay's limit; the forecaster's own chance of this, stated with the estimate: 75%; the middle value lies on the limit itself.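

No step can be read among compound 1, compound 2 and compound 3 in this assay, as all three stand at the same limit: the limit of > 100000 nM in this assay, at which 3 of the 3 values shown sit.

The compounds shown leave open how far each lies from that limit, and whether chloro, bromo or hydrogen on the aromatic carbon makes any difference to the read-out.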